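Carboxy to nitro on the aryl group of compound 3

The compounds below may be only part of what the source reports. "The series", "measured", "known", "first", "only" and "open" are said of these compounds alone.

Working notes on the series. Compound 1 `CC(C)Cc1nn(-c2nccs2)cc1C(=O)Nc1ccc(F)cc1` gives in a toxicity assay on HepG2 2.2.15 cells (Homo sapiens) for cytotoxicity, read by CCK-8 assay, with a stated time of 8 days (a lower number here means that less compound is tolerated, a higher number that more compound is tolerated), a half-maximal cytotoxic concentration of 83700 nM. Compound 2 `CC(C)Cc1nn(-c2cccc(F)c2)cc1C(=O)NCc1ccncc1` returns in this assay only a limit, > 100000 nM. Compound 3 `CCOC(=O)c1cn(-c2ccc(C(=O)O)cc2)nc1CC(C)C` likewise returns in this assay only the limit > 100000 nM, so no numbered value exists for it. Compound 3 thus stands at the limit of > 100000 nM in this assay, at which 2 of the 3 values shown sit, and nothing ranks it against the other two. Compound 4 `CCOC(=O)c1cn(-c2ccc([N+](=O)[O-])cc2)nc1CC(C)C` is the unmeasured partner of compound 3: nitro in place of carboxy on an aromatic carbon. For the measured compounds named here, no measured pair in this set shows what such a change does in this assay, so no step beyond the scatter is foreseen. Compound 4 is expected to be tolerated about as well, with an estimated 90000 nM (range 40000 nM to 200000 nM), an expected step of an at least 1.1-fold lower number from compound 3 to compound 4 (0.04 log units; that floor lies within the scatter) no larger than the scatter.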

Compound 4, half-maximal cytotoxic concentration: > 100000 nM
Compound 4: a limit, no number; the forecaster's own chance of this, stated with the estimate: 55%; middle value at least 1.1-fold (0.04 log units) from the limit.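

In this assay compound 4, like compound 3, returns only a limit, so no step can be read between compound 3 and compound 4: the limit of > 100000 nM in this assay, at which 3 of the 4 values shown sit.

Open remains how nitro and carboxy on the aryl group compare, and how compounds 2, 3 and 4 rank among themselves.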